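The source may hold more compounds than are shown below. What is called first, only, known or untested is meant among the compounds shown, and "the series" means these compounds.

Measured so far:
compound 1 `CN1C(=O)c2cnn(Cc3ccccc3)c2N2C1=N[C@@H]1CCC[C@@H]12` — 29000 nM
compound 2 `CN1C(=O)c2c(nn(C)c2Cc2ccccc2)N2CC3(CCCC3)N=C12` — 60 nM
compound 3 `CN1C(=O)c2c(nn(C)c2Cc2ccccc2)N2C1=N[C@@H]1CCC[C@@H]12` — 55 nM; 160 nM (2 entries)

In an assay on isolated protein for inhibition of phosphodiesterase 1 (Bos taurus) (on this read-out lower numbers stand for stronger inhibition and higher numbers for weaker inhibition), compound 1 gives 29000 nM, the highest of the two numbers available; its nearest neighbour, compound 2, sits far lower at 60 nM, beyond the scatter. Compound 3 has several entries, (the several entries of compound 3 in this assay, 55 nM; 160 nM (2 entries)), and so carries no single number. Compound 1 and compound 4 `Cc1nn(Cc2ccccc2)c2c1C(=O)N(C)C1=N[C@@H]3CCC[C@@H]3N12` share the core of compound 1; the difference is methyl in place of hydrogen on an aromatic carbon. Going by the values given here, compounds 2 and 3 carry their benzyl group elsewhere, so they show no step of this kind. For this assay a step of modest size from compound 1 to compound 4 is expected, towards a lower number, with no firm basis beyond the numbers shown. Compound 4 is estimated at 12000 nM, with a range of 2500 nM to 50000 nM; the step of a 2.4-fold lower number from compound 1 to compound 4 (0.38 log units; beyond the scatter) is what this estimate means.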

Compound 4, half-maximal inhibitory concentration: 2000 nM
For compound 4 the middle estimate is 6.0-fold (0.78 log units) above the measured one; the measured number lies below the stated range.
By their numbers in this assay, from the lowest: compound 2; then compound 4; then compound 1.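

Methyl in place of hydrogen on this aromatic carbon, read in this assay with nothing else changed, gives a 15-fold lower number from compound 1 to compound 4 (1.16 log units; beyond the scatter) as a large step. Going by these compounds alone, this is the first reading at this position, and it shows that the number responds strongly to this single added methyl on the shared core. No measurement shown gives a cause for the step.

Open, as far as these compounds go, is whether ethyl, a longer chain or an amine on this aromatic carbon moves the number further. Also open, from the compounds shown here alone, is whether the step holds with the benzyl group elsewhere on the core.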